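The compounds below may be only part of what the source reports. "The series", "measured", "known", "first", "only" and "open" are said of these compounds alone.

Notes on the series. Compound 1 `Cn1nc(-c2ccccc2)c2cc(C(=N)Nc3ccccc3)ncc21` in a functional assay on PC-3 cells (Homo sapiens) for cytotoxicity, read by MTT assay, with a stated time of 72 h (a higher number here means a weaker inhibitor, a lower number a stronger inhibitor), gives 17300 nM, the lower of the two numbers in hand. Compound 2 `CN1CCN(c2ccc(NC(=N)c3cc4cn[nH]c4cn3)cc2)CC1` in this assay gives 45400 nM, a higher number than compound 1 and beyond the scatter; the two differ in more than one place, so their values are only compared, not read as a step. Compound 3 `COc1ccc(Cn2nc(-c3ccccc3)c3cc(C(=N)Nc4ccccc4)ncc32)cc1` carries 4-methoxyphenyl in place of hydrogen on a saturated chain carbon bound to an aromatic nitrogen. Going by the values given here, no measured pair shows this change, so its size is unknown. A step of roughly a 1.7-fold lower number from compound 1 to compound 3 (0.24 log units; within the scatter) toward a lower number is expected, though one within the scatter cannot be excluded. Compound 3 is expected at 10000 nM, in the range 3000 nM to 40000 nM.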

Compound 3, half-maximal inhibitory concentration: 6300 nM
Estimate against measurement, compound 3: 1.6-fold (0.20 log units) above; measured number inside the range.
By their numbers in this assay, from the lowest: compound 3; then compound 1; then compound 2.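

At the saturated chain carbon bound to an aromatic nitrogen, the core of compound 1 accepts a much larger group without loss in this assay: 4-methoxyphenyl in place of hydrogen, which turns methyl into 4-methoxybenzyl, gives a 2.7-fold lower number from compound 1 to compound 3 (0.44 log units; beyond the scatter). Going by these compounds alone, this is the first readable step, and it shows that this position affects the number, although only modestly. No measurement at hand gives a reason for the step.

On these data alone, whether the methoxy group or the added aromatic ring carries the step remains open. So does what an unsubstituted benzyl, a 4-chlorobenzyl or a longer alkyl chain would give at this position.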